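Fluoro scan on the anilide ring: cytotoxicity notes

The source may report more compounds than this note shows. Statements on the series, on what has been measured and on what is new or still open speak of the compounds shown alone.

Measured so far in an ADME assay on MT2 cells (Homo sapiens) for cytotoxicity, read by XTT assay, with a stated time of 4 days; a higher number here means that more compound is tolerated, a lower number that less compound is tolerated:
- compound 1 `Cc1nc(C(NC(=O)C(=O)Nc2ccc(Cl)cc2)C2CCCCN2)sc1CO`: compound 1 gives > 108000 nM, which is a limit of the assay, not a number.
- compound 2 `Cc1nc(C(NC(=O)C(=O)Nc2ccc(Cl)c(F)c2)C2CCCCN2)sc1CO`: compound 2 gives 77800 nM.
- compound 3 `Cc1nc(C(NC(=O)C(=O)Nc2ccc(F)cc2)C2CCCCN2)sc1CCO`: compound 3 gives 109000 nM.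

From compound 1 to compound 2 the change is fluoro in place of hydrogen on an aromatic carbon, and it brings an at least 1.3-fold lower number from compound 1 to compound 2 (0.14 log units; that floor lies within the scatter); the starting point is only known as a limit, (the limit of > 108000 nM in this assay, at which 1 of the 3 values shown sits). The difference between the core of compound 1 and the core of compound 3 is not broken down here.

Compound 4 `Cc1nc(C(NC(=O)C(=O)Nc2ccc(F)cc2F)C2CCCCN2)sc1CCO` differs from compound 3 by fluoro in place of hydrogen on an aromatic carbon. The surroundings differ: in compound 2 the new fluoro sits ortho to a chloro group and meta to a large group, in compound 4 ortho to a large group and meta to a fluoro group, so this is the same kind of change, not the same. For compound 4 in this assay a step of a 1.3-fold lower number from compound 3 to compound 4 (0.11 log units; within the scatter) is expected, resting on the small step of an at least 1.3-fold lower number from compound 1 to compound 2 (0.14 log units; that floor lies within the scatter) for the earlier pair. Compound 4 is thus estimated at 85000 nM, between 40000 nM and 150000 nM.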

Compound 4, half-maximal cytotoxic concentration: > 105000 nM
Compound 4: no number, only a limit; the forecaster's own chance of this, stated with the estimate: 25%; at least 1.2-fold (0.09 log units) between middle value and limit.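

In this assay, among the compounds shown here, compound 4 gives > 105000 nM, which is a limit and not a number, so no step from compound 3 to compound 4 can be read. The compounds shown leave open whether 2,4-difluorophenyl in place of 4-fluorophenyl changes the tolerated concentration at all.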